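A few compounds are considered here, and "the series" means these few. Any claim that something is new, unique, unknown or untested is made for them only; others in the source may bear on it.

Measured in an ADME assay on MT4 cells (Homo sapiens) for cytotoxicity, read by MTT assay; a lower number here means that less compound is tolerated, a higher number that more compound is tolerated:
compound 1 `O=C(CSc1nnnn1-c1cccc2ccccc12)N/N=C/c1ccc(Cl)cc1`, a limit: > 295000 nM
compound 2 `O=C(CSc1nnnn1-c1cccc2ccccc12)N/N=C/c1cccc(Cl)c1`: 240000 nM
compound 3 `COc1ccc(/C=N/NC(=O)CSc2nnnn2-c2cccc3ccccc23)cc1`, a limit: > 298000 nM

For the measured compounds named here, compound 2 holds the only number in this assay; the two other values are limits, the limit of > 295000 nM in this assay, at which 1 of the 3 values shown sits, and (the limit of > 298000 nM in this assay, at which 1 of the 3 values shown sits). Compound 4 `O=C(CSc1nnnn1-c1cccc2ccccc12)N/N=C/c1ccccc1O` differs from compound 2 in one place: 2-hydroxyphenyl in place of 3-chlorophenyl on a carbon with a double bond to nitrogen. The steps that touch compound 2 are an at least 1.2-fold lower number from compound 1 to compound 2 (0.08 log units; that floor lies within the scatter) and an at least 1.2-fold higher number from compound 2 to compound 3 (0.09 log units; that floor lies within the scatter); both floors sit within the scatter, and a step that the two limits leave unreadable from compound 1 to compound 3. No change at this carbon has so far moved this assay beyond the scatter, so for compound 4 no step beyond the scatter is expected in either direction, with a fair chance that only a limit is returned. The expected step is a 1.1-fold higher number from compound 2 to compound 4 (0.05 log units; within the scatter). Compound 4 is estimated at 270000 nM, within 140000 nM to 400000 nM.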

Compound 4, half-maximal cytotoxic concentration: 4850 nM
Compound 4: middle estimate off by 56-fold (1.75 log units), on the high side, outside the stated range (below it).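

In this assay, the carbon with a double bond to nitrogen is no longer a silent position: 2-hydroxyphenyl gives a 49-fold lower number from compound 2 to compound 4 (1.69 log units; beyond the scatter). The same change also gives an at least 61-fold lower number from compound 3 to compound 4 (1.78 log units; beyond the scatter) and an at least 60-fold lower number from compound 1 to compound 4 (1.78 log units; beyond the scatter); both of these are floors, as compound 3 and compound 1 carry limits. No measurement shown accounts for this drop.

The compounds shown leave open whether the drop follows the hydroxy group itself or its place on the ring. A 2-methoxyphenyl or a 3-hydroxyphenyl at this carbon would bear on that question.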